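Swapping the outer aromatic ring for a propyl chain

The compounds below may be only part of what the source reports. "The series", "measured", "known", "first", "only" and "open" are said of these compounds alone.

In a functional assay on MiaPaCa cells (Homo sapiens) for antiproliferative activity, read by sulforhodamine B assay, with a stated time of 48 h (a higher number here means a weaker inhibitor of growth, a lower number a stronger inhibitor of growth), compound 2 `COc1ccc(-c2cn(CCCN3C(=O)COc4ccccc43)nn2)cc1` gives 15700 nM. Within the data shown here, this is the only outright number in the set. Compound 1 `CCCCCc1ccc(-c2cn(CCCN3C(=O)COc4ccccc43)nn2)cc1` returns only a limit, > 100000 nM, so for compound 1 no number is known. Among the measured compounds shown here, the one step between these two, an at least 6.3-fold lower number from compound 1 to compound 2 (0.80 log units; beyond the scatter), shows that changing the group on the outer aromatic ring can move the result beyond the usual scatter, with the reading on compound 1 bounded by the limit of > 100000 nM in this assay, at which 1 of the 2 values shown sits.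

Compound 3 `CCCc1cn(CCCN2C(=O)COc3ccccc32)nn1` has not yet been measured. It differs from compound 2 in one place: propyl in place of 4-methoxyphenyl on an aromatic carbon. The measured step concerns only what sits on that outer ring, not the removal of the ring itself, so it does not test this change directly; it shows only that this region of the molecule can matter. Compound 3 is therefore expected to land near 40000 nM, within a range from 10000 nM to 150000 nM. The expected step is a 2.5-fold higher number from compound 2 to compound 3 (0.41 log units; beyond the scatter), with a real chance that only a limit is returned.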

Compound 3, concentration for 50% growth inhibition: 2600 nM
Estimate against measurement, compound 3: 15-fold (1.19 log units) above, and the stated range ends above it.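

Removing the outer aromatic ring altogether does not weaken the compound in this assay: swapping 4-methoxyphenyl for propyl gives a 6.0-fold lower number from compound 2 to compound 3 (0.78 log units; beyond the scatter). The earlier pair changed only the group carried on that ring, so it could not show that the ring itself can be dispensed with at this aromatic carbon, and that a plain chain with no ring and no hydrogen-bond acceptor can stand there and give a stronger inhibitor of growth than compound 2 does. Among these compounds, compound 1 remains a limit and not a number, so the only step that can be sized exactly is this new one, and the comparison with compound 1 stays bounded: the limit of > 100000 nM in this assay, at which 1 of the 3 values shown sits.

With a single chain at this position, the compounds shown cannot separate the loss of the ring from the reduction in the size of the group. On these data alone, whether a shorter chain such as ethyl, a longer chain such as hexyl, or a propyl chain ending in an amine or a carboxylic acid would give a lower or a higher number remains open.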